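Second chloro on the purine core: expectation for compound 3

The source may report more compounds than this note shows. Statements on the series, on what has been measured and on what is new or still open speak of the compounds shown alone.

Measured compounds:
compound 1 `ClCc1cccc(Cn2cnc3ncnc(Cl)c32)c1`, 2080 nM
compound 2 `ClCc1cccc(Cn2cnc3c(Cl)ncnc32)c1`, 11800 nM

Of the compounds shown here, two have been measured in a functional assay on NCI-H460 cells (Homo sapiens) for cytotoxicity, read by sulforhodamine B assay, with a stated time of 48 h; a lower number here means a stronger inhibitor of growth, a higher number a weaker inhibitor of growth. Compound 1 `ClCc1cccc(Cn2cnc3ncnc(Cl)c32)c1` gives 2080 nM there. Compound 2 `ClCc1cccc(Cn2cnc3c(Cl)ncnc32)c1` gives 11800 nM in this assay, the highest of the two numbers; its nearest neighbour is compound 1, whose number is lower by a margin beyond the scatter. Among the compounds with values here, no single-point step between measured compounds is available, so the two values show only that compound 2 is the weaker growth inhibitor of the pair.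

Compound 3 `ClCc1cccc(Cn2cnc3c(Cl)nc(Cl)nc32)c1` is not yet measured. It differs from compound 2 by chloro in place of hydrogen on an aromatic carbon. Within the data shown here, with no measured step of this kind to lean on, the change is expected to move the number modestly downward, with the step from compound 2 to compound 3 estimated at a 2.0-fold lower number from compound 2 to compound 3 (0.29 log units; within the scatter). Compound 3 is therefore expected to give about 6000 nM in this assay, within a range from 1500 nM to 20000 nM.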

Compound 3, concentration for 50% growth inhibition: 2340 nM
Beside the measured number, compound 3's estimate is 2.6-fold (0.41 log units) above it; measured number inside the range.
By their numbers in this assay, from the lowest: compounds 1 and 3 (each within the scatter of the next); then compound 2.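

In this assay, chloro in place of hydrogen on the aromatic carbon between two ring nitrogen atoms gives a 5.0-fold lower number from compound 2 to compound 3 (0.70 log units; beyond the scatter) and so provides the first single-point step among these compounds. Within the data shown here, the earlier pair showed only that two compounds differed; this step shows that the position between the two ring nitrogen atoms responds to substitution, with compound 3 the stronger growth inhibitor of the two. A single chlorine atom, a change of one heavy atom, is enough to produce a difference beyond the scatter.

On these data alone, whether an amine, a methoxy group or a methyl group on this carbon would act as chloro does remains open. So does whether the same chloro step would hold on the core of compound 1. Nothing measured here accounts for the size of this step.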